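Swapping the Side Group on a Thromboxane Synthase Inhibitor Series

The source may report more compounds than this note shows. Statements on the series, on what has been measured and on what is new or still open speak of the compounds shown alone.

Of the compounds shown here, two have been measured. Compound 1, `N#Cc1ccccc1C1OCC(C/C=C\CCC(=O)O)C(c2cccnc2)O1`, gives 54 nM in an assay for inhibition of Thromboxane-A synthase (Homo sapiens), using microsomes; a lower number here means a stronger inhibitor, a higher number a weaker inhibitor. Compound 2, `CSc1ccccc1OC(C)(C)C1OCC(C/C=C\CCC(=O)O)C(c2cccnc2)O1`, gives 36 nM in this assay; this is the lowest of the two numbers, but its gap to compound 1 lies within the scatter, so the two cannot be ranked. Compound 3, `CC(C)(Cc1ccc(F)cc1C#N)C1OCC(C/C=C\CCC(=O)O)C(c2cccnc2)O1`, has not yet been measured in this assay. It differs from compound 2 in one place: a group of 10 heavy atoms (8 carbon, 1 nitrogen, 1 fluorine; one six-membered aromatic ring of carbon only) in place of a group of 9 heavy atoms (7 carbon, 1 oxygen, 1 sulfur; one six-membered aromatic ring of carbon only), on a saturated chain carbon bound to two saturated chain carbons and a saturated ring carbon. Among the compounds with values here, no step between measured compounds bears directly on this change. Compound 1 already carries a nitrile on its aromatic ring and gives 54 nM in this assay, a number close to that of compound 2, so the new side group is not expected to move the result far. The step is therefore expected to stay within the scatter: a 1.4-fold higher number from compound 2 to compound 3 (0.14 log units; within the scatter). For compound 3 the estimate is 50 nM, within a range from 20 nM to 150 nM.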

Compound 3, half-maximal inhibitory concentration: < 10 nM
Compound 3: a limit, no number; the forecaster's own chance of this, stated with the estimate: 3%; middle value at least 5.0-fold (0.69 log units) away from the limit.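

Within the data shown here, at the saturated chain carbon bound to two saturated chain carbons and a saturated ring carbon, the side group turns out to matter, which the earlier compounds, with no step between them, could not show: exchanging 2-(methylsulfanyl)phenoxy for the aromatic group carrying a nitrile and a fluorine gives an at least 3.6-fold lower number from compound 2 to compound 3 (0.55 log units; beyond the scatter). In this assay compound 3 gives < 10 nM, which is a limit of the assay and not a number. The step is therefore a minimum, and its full size remains unknown: the limit of < 10 nM in this assay, at which 1 of the 3 values shown sits.

The single change replaces several features at once, so the compounds shown do not tell whether the nitrile, the fluorine or the link to the aromatic ring carries the step. They also leave open how an amine or a methoxy group on that aromatic ring would read in this assay.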